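Moving the Fluorine on the Phenyl Group of Compound 3

The source may report more compounds than this note shows. Statements on the series, on what has been measured and on what is new or still open speak of the compounds shown alone.

For the measured compounds named here, in a functional assay on B16 cells (Mus musculus) for cytotoxicity, read by CCK-8 assay, with a stated time of 24 h (a lower number here means a stronger inhibitor, a higher number a weaker inhibitor), compound 3 `COc1ccccc1Oc1c(N)nc(-c2cccc(F)c2)nc1OCCO` gives 20900 nM, the highest number of the three compounds measured so far. Compound 2 `COc1ccccc1Oc1c(N)nc(-c2ccc(C)cc2)nc1OCCO` gives 8430 nM. Compound 1 `COc1ccccc1Oc1c(N)nc(-c2ccc(F)cc2)nc1Cl`, which lacks the 2-hydroxyethoxy group, gives 2990 nM.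

The next compound is compound 4 `COc1ccccc1Oc1c(N)nc(-c2ccc(F)cc2)nc1OCCO`, which has 4-fluorophenyl in place of 3-fluorophenyl (4-fluorophenyl in place of 3-fluorophenyl on an aromatic carbon). The group sits para to the 2-methoxyphenoxy group. Going by the values given here, only one measured step bears directly on this change: a 2.5-fold higher number from compound 2 to compound 3 (0.39 log units; beyond the scatter), which is modest and replaces 4-methylphenyl with 3-fluorophenyl. It is an imperfect guide, since it changes the substituent as well as its position. Among the compounds with values here, compound 1 also carries 4-fluorophenyl, but no measured step isolates that group's contribution. Going from 3-fluorophenyl to 4-fluorophenyl is therefore expected to reverse much of that step, giving a modest fall in the number: a 2.1-fold lower number from compound 3 to compound 4 (0.32 log units; beyond the scatter) is the estimated step. For compound 4 the estimated value is 10000 nM, with an expected range from 4500 nM to 21000 nM.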

Compound 4, half-maximal inhibitory concentration: 30100 nM
The estimate for compound 4 lay 3.0-fold (0.48 log units) below the measured number; the measured number lies above the stated range.
By their numbers in this assay, from the lowest: compound 1; then compound 2; then compounds 3 and 4 (each within the scatter of the next).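

In this assay the move from 3-fluorophenyl to 4-fluorophenyl gives a 1.4-fold higher number from compound 3 to compound 4 (0.16 log units; within the scatter) and so does not separate the two placings of fluorine on this phenyl group. With the 2-hydroxyethoxy group held, fluoro in place of methyl gives a 3.6-fold higher number from compound 2 to compound 4 (0.55 log units; beyond the scatter) as the single change on the phenyl group, while with 4-fluorophenyl held, 2-hydroxyethoxy in place of chloro gives a 10-fold higher number from compound 1 to compound 4 (1.00 log units; beyond the scatter) and is the largest single change among these compounds. No measurement shown here accounts for any of these steps.

Chloro appears only alongside 4-fluorophenyl, so it remains open whether the step to 2-hydroxyethoxy would be as large with 3-fluorophenyl or 4-methylphenyl. The compounds shown also leave open what an amine or a longer ether chain would give in place of the 2-hydroxyethoxy group.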